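Hydroxy to methoxy in a small antiproliferative series

The source may report more compounds than this note shows. Statements on the series, on what has been measured and on what is new or still open speak of the compounds shown alone.

Values so far in a functional assay on SR cells (Homo sapiens) for antiproliferative activity, read by sulforhodamine B assay, with a stated time of 48 h; a lower number here means a stronger inhibitor of growth, a higher number a weaker inhibitor of growth
- compound 1 `O=C(NCCCNc1cc(-c2cn(-c3ccccc3)nc2-c2cccc(O)c2)ccn1)Nc1ccc(F)cc1` gives 13800 nM
- compound 2 `O=C(NCCCNc1cc(-c2cn(-c3ccccc3)nc2-c2cccc(O)c2)ccn1)Nc1cccc(C(F)(F)F)c1` gives 12800 nM

Compound 1 and compound 2 lie within the scatter of each other, so neither ranks ahead. Among the compounds with values here, the only measured step, a 1.1-fold lower number from compound 1 to compound 2 (0.03 log units; within the scatter), puts 3-(trifluoromethyl)phenyl in place of 4-fluorophenyl on an amide-type nitrogen.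

Compound 3 `COc1cccc(-c2nn(-c3ccccc3)cc2-c2ccnc(NCCCNC(=O)Nc3ccc(F)cc3)c2)c1` has not been measured. It differs from compound 1 by methyl in place of hydrogen on an oxygen on an aromatic ring, which is methyl in place of hydrogen on an oxygen on an aromatic ring, or 3-hydroxyphenyl to 3-methoxyphenyl. Within the data shown here, no measured step involves this change, and the single step available concerns a different group, so it gives only weak guidance on size. Among the measured compounds shown here, the data hold no pair that tests hydroxy against methoxy. No shift beyond the scatter is therefore expected in this assay, and no direction is favoured, though the range is kept wide. The estimate starts from compound 1 at 13800 nM and stays close to it. The expected change is a 1.1-fold lower number from compound 1 to compound 3 (0.03 log units; within the scatter) in size. For compound 3 the estimated value is 13000 nM, with an expected range from 5500 nM to 32000 nM.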

Compound 3, concentration for total growth inhibition: > 37000 nM
Compound 3 was reported as a limit; the forecaster's own chance of this, stated with the estimate: 10%; middle value at least 2.8-fold (0.45 log units) away from the limit.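

In this assay, within the data shown here, hydroxy to methoxy on the aromatic ring gives an at least 2.6-fold higher number from compound 1 to compound 3 (0.42 log units; beyond the scatter), the first step that lies beyond the scatter, whereas the change on the amide-type nitrogen, a 1.1-fold lower number from compound 1 to compound 2 (0.03 log units; within the scatter), stays within it. Among these compounds, the result for compound 3 is a limit and not a number: the limit of > 37000 nM in this assay, at which 1 of the 3 values shown sits. Within this one pair, the oxygen on the aromatic ring is therefore a place where a single added methyl weakens growth inhibition measurably, which the earlier compounds, both carrying the hydroxy, could not show.

This single pair does not separate the loss of the hydrogen from the presence of the methyl, and a fluoro or an amino group in place of the hydroxy, or an ethoxy on the same oxygen, would bear on that question. It also leaves open whether the same change behaves alike with the 3-(trifluoromethyl)phenyl group of compound 2, since the hydroxy to methoxy step is shown here with the 4-fluorophenyl group only.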